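The source may hold more compounds than are shown below. What is called first, only, known or untested is meant among the compounds shown, and "the series" means these compounds.

Measured in an ADME assay on J774.1 cells (Mus musculus) for cytotoxicity, read by resazurin assay, with a stated time of 48 h; on this read-out higher numbers stand for weaker inhibition and lower numbers for stronger inhibition:
- compound 1 `CCCn1cc(C(=O)NCc2ccc(OC)cc2)c(=O)c2cc(F)c(N3CCC(C(N)=O)CC3)cc21`: 41400 nM
- compound 2 `CCCCn1cc(C(=O)O)c(=O)c2cc(F)c(N3CCC(C(N)=O)CC3)cc21`: > 100000 nM, a limit of the assay and not a number
- compound 3 `CCCn1cc(C(=O)O)c(=O)c2cc(F)c(N3CCC(C(N)=O)CC3)cc21`: > 100000 nM, also a limit of the assay and not a number

Compound 1 is the only one of these with a true number, while the other two rest on a limit: the limit of > 100000 nM in this assay, at which 2 of the 3 values shown sit.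

Compound 4 `COc1ccc(CNC(=O)c2cn(C3CC3)c3cc(N4CCC(C(N)=O)CC4)c(F)cc3c2=O)cc1` keeps the core of compound 1 and changes in one place: cyclopropyl in place of propyl on an aromatic nitrogen. In short, cyclopropyl stands in place of propyl on an aromatic nitrogen.

Two measured steps are available, and neither settles the question. The change at a carbonyl carbon gave an at least 2.4-fold higher number from compound 1 to compound 3 (0.38 log units; beyond the scatter), but that lies elsewhere in the molecule. Only a step that the two limits leave unreadable from compound 2 to compound 3 touches the chain on the aromatic nitrogen, and it gives no usable size.

With no readable step at this place, the expectation stays anchored on compound 1 at 41400 nM. The expected change is a 1.0-fold lower number from compound 1 to compound 4 (0.01 log units; within the scatter), with no shift beyond the scatter in either direction in this assay. For compound 4 the expected value is 40000 nM, with an estimated range from 16000 nM to 95000 nM.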

Compound 4, half-maximal inhibitory concentration: > 100000 nM
Compound 4: a limit, no number (the forecaster's own chance of this, stated with the estimate: 15%); middle value at least 2.5-fold (0.39 log units) from the limit.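

On the aromatic nitrogen, cyclopropyl in place of propyl gave an at least 2.4-fold higher number from compound 1 to compound 4 (0.38 log units; beyond the scatter) in this assay, and a higher number here stands for weaker inhibition. Going by these compounds alone, this is the first readable sign that this position can move the read-out, since the step from compound 2 to compound 3 cannot be read. The two groups hold the same count of 3 carbon atoms and differ in the three-membered ring of cyclopropyl, and the full size of the step stays hidden because compound 4 gives a limit and not a number: the limit of > 100000 nM in this assay, at which 3 of the 4 values shown sit.

The compounds shown leave open how an ethyl or a cyclobutyl group on this aromatic nitrogen would read, and so whether the ring itself goes with the change. They also leave compound 2, compound 3 and compound 4 unranked against one another, as all three rest on a limit.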